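The source may report more compounds than this note shows. Statements on the series, on what has been measured and on what is new or still open speak of the compounds shown alone.

The series is assessed in an ADME assay on Vero cells (Chlorocebus sabaeus) for cytotoxicity, read by MTT assay, with a stated time of 72 h; on this read-out lower numbers stand for higher toxicity in this test and higher numbers for lower toxicity in this test. Compound 1 `CC(C)Cc1ccc(C(=O)/C=C/c2ccc(C(=O)O)cc2)cc1` stands apart from the amide-linked pair. In this assay compound 1 gives < 10 ug/mL, a limit of the assay rather than a number (the limit of < 10 ug/mL in this assay, at which 1 of the 3 values shown sits). Compound 2 `COC(=O)c1cc(-c2cccc(NC(=O)c3ccc(/C=C/C(=O)c4cccc(OC)c4)cc3)c2)on1` is the starting point of the step followed here. In this assay compound 2 gives > 100 ug/mL, again a limit and not a measured number (the limit of > 100 ug/mL in this assay, at which 1 of the 3 values shown sits). Compound 3 `COC(=O)c1cc(-c2cccc(NC(=O)c3ccc(/C=C/C(=O)c4ccc(F)cc4F)cc3)c2)on1` carries 2,4-difluorophenyl in place of 3-methoxyphenyl on a carbonyl carbon. In this assay compound 3 gives > 40 ug/mL, likewise a limit (the limit of > 40 ug/mL in this assay, at which 1 of the 3 values shown sits). The measured step that the two limits leave unreadable from compound 2 to compound 3 is unreadable in size and direction; both of its ends are limits. Compound 4 `COC(=O)c1cc(-c2cccc(NC(=O)c3ccc(/C=C/C(=O)c4cccc(Br)c4)cc3)c2)on1` differs from compound 2 by bromo in place of methoxy on an aromatic carbon, the 3-methoxyphenyl becoming 3-bromophenyl. Going by the values given here, no measured step bears directly on this change, and the only step between measured compounds cannot be read. The account therefore expects a step of an at least 1.2-fold lower number from compound 2 to compound 4 (0.09 log units; that floor lies within the scatter), one that stays within the scatter. Compound 4 is estimated at 80 ug/mL, within 30 ug/mL to 150 ug/mL, with a real chance that this assay again returns only a limit.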

Compound 4, half-maximal cytotoxic concentration: > 100 ug/mL
Compound 4: only a limit was reported; the forecaster's own chance of this, stated with the estimate: 65%; at least 1.2-fold (0.09 log units) between middle value and limit.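

In this assay compound 4 gives > 100 ug/mL as a limit of the assay and not a number. Its steps from compound 2 and from compound 3 therefore cannot be read. The compounds shown leave open whether compound 2, compound 3 and compound 4 differ at all in this read-out.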